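The source may hold more compounds than are shown below. What is called first, only, known or untested is meant among the compounds shown, and "the series" means these compounds.

Of the compounds shown here, two have so far been tested for agonist activity in a functional assay on isolated protein for agonist activity at Free fatty acid receptor 1 (Homo sapiens), read by HTRF and inositol phosphate accumulation, with a stated time of 60 min; on this read-out higher numbers stand for an effect only at larger amounts of compound and lower numbers for an effect already at smaller amounts. Compound 1 (`O=C(O)CCCOc1ccc(-c2ccccc2Oc2ccccc2)cc1`) is one of them. In this assay compound 1 gives only a limit, > 9950 nM, and no number. Compound 2 (`Cc1cc(OCCCC(=O)O)ccc1-c1cc(OC(F)(F)F)ccc1Cl`) likewise returns only a limit in this assay, > 9950 nM. Compound 2 thus stands at the limit where both tested values sit, as summarised in the limit of > 9950 nM in this assay, at which 2 of the 2 values shown sit; the numbers do not set it apart from compound 1. Compound 3 (`O=C(O)CCCOc1ccc(-c2cc(OC(F)(F)F)ccc2Cl)c(F)c1`) is not yet measured. It differs from compound 2 by fluoro in place of methyl on an aromatic carbon, the new group sitting ortho to a large group and meta to the 3-carboxypropoxy group. For the measured compounds named here, no measured step between compounds exists to guide the size of this change. The expected step is a step that the limit leaves unreadable from compound 2 to compound 3, none beyond the scatter. Compound 3 is therefore estimated at 15000 nM in this assay, with a range from 5000 nM to 50000 nM, and most likely again only a limit.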

Compound 3, half-maximal effective concentration: > 9950 nM
Compound 3: only a limit was reported; the forecaster's own chance of this, stated with the estimate: 70%; the middle value does not contradict the limit.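

Compound 3, like compound 2, gives only a limit in this assay, so no step can be read between the two: the limit of > 9950 nM in this assay, at which 3 of the 3 values shown sit. The compounds shown leave open what fluoro in place of methyl on an aromatic carbon does to the half-maximal effective concentration.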